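This account rests on a few compounds, and the source may have more. Where it says the series, first, only, none or still open, it means among the compounds named here.

Compound 1 `N=C(S)CCn1nc(-c2cccs2)ccc1=O`: 50.2%; compound 2 `N=C(S)CCCCCCN1N=C(c2ccccc2)CCC1=O`: 68.3%; compound 3 `CC(Cn1ncccc1=S)C(=N)S`: -1%.

All three were run in a functional assay on the whole organism (stomach) for inhibition, with Rattus norvegicus as the target, at a dose of 100 mg/kg by the intraduodenal route; on this read-out higher numbers stand for more inhibition at the one dose given (going by the name of the read-out) and lower numbers for less inhibition. Compound 2 stands highest of the three; compound 1 lies nearest, a gap beyond the scatter, and compound 3 lies furthest, also beyond the scatter. Compound 4 `N=C(S)CCN1N=C(c2ccccc2)CCC1=O` has not been measured. It differs from compound 2 in one place: a group of 3 heavy atoms (1 carbon, 1 nitrogen, 1 sulfur; no ring) in place of a group of 7 heavy atoms (5 carbon, 1 nitrogen, 1 sulfur; no ring), on a saturated chain carbon, two bonds along the chain from an amide-type nitrogen in a ring. Going by the values given here, no pair of measured compounds differs in a single place, so no measured step guides this change. Compound 1 carries the same group of 3 heavy atoms on its own core and gives 50.2%, a reading below that of compound 2. For compound 4 the expected step of a number 18.3 percentage points lower from compound 2 to compound 4 (beyond the scatter) is therefore a modest fall, uncertain in size. Compound 4 is estimated at 50%, with a range from 25% to 75%.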

Compound 4, a percentage reported as inhibition, in the whole organism at one dose (the size of the read-out at that dose, not a potency): 38.2%
Estimate against measurement, compound 4: 11.8 percentage points above; measured number inside the range.
By their numbers in this assay, from the lowest: compound 3; then compound 4; then compound 1; then compound 2.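

In this assay, replacing the group of 7 heavy atoms with the group of 3 heavy atoms gives a number 30.1 percentage points lower from compound 2 to compound 4 (beyond the scatter), so this saturated chain carbon is not indifferent to the length of the group it carries. The two groups have the same hydrogen-bond donors and acceptors and no net charge, which leaves size as the difference that can be counted. Nothing given here explains the fall.

Still open, on these data alone, is how inhibition runs at intermediate lengths or with a longer chain, and whether a terminal amine or carboxylic acid would retain it. As far as these compounds go, each reading comes from a single dose, so potency also remains open.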